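Methyl for Trifluoromethyl: Does a Weak Compound Stay Weak?

The source may hold more compounds than are shown below. What is called first, only, known or untested is meant among the compounds shown, and "the series" means these compounds.

Compound 1 `Cc1cc(=O)oc2cc(Sc3cccc(Cl)n3)ccc12` — 920 nM
Compound 2 `Cc1cc(=O)oc2cc(SC3CCOC3=O)ccc12` — > 36100 nM
Compound 3 `Cc1cc(=O)oc2cc(SCc3cccc(C(F)(F)F)c3)ccc12` — > 28500 nM

In a functional assay on KB cells (Homo sapiens) for antiproliferative activity, read by sulforhodamine B assay, with a stated time of 72 h (a lower number here means a stronger inhibitor of growth, a higher number a weaker inhibitor of growth), compound 1 gives 920 nM. Compound 2 reaches only the assay limit of > 36100 nM, which is a limit and not a measured number. Compound 3 likewise reaches only the assay limit of > 28500 nM. Two of the three values shown are such limits (the limit of > 28500 nM in this assay, at which 1 of the 3 values shown sits, (the limit of > 36100 nM in this assay, at which 1 of the 3 values shown sits)), so compound 3 stands at the edge of what this assay reports, with no number of its own.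

Compound 4 `Cc1cccc(CSc2ccc3c(C)cc(=O)oc3c2)c1` differs from compound 3 by methyl in place of trifluoromethyl on an aromatic carbon. Among the measured compounds shown here, no measured step of this kind is available, so the expected change in this assay is none beyond the scatter, a step that the limit leaves unreadable from compound 3 to compound 4. Compound 4 is therefore estimated at 30000 nM, within 8000 nM to 100000 nM, and may again show only a limit.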

Compound 4, concentration for 50% growth inhibition: > 33700 nM
Compound 4 was reported as a limit; the forecaster's own chance of this, stated with the estimate: 65%; middle value at least 1.1-fold (0.05 log units) away from the limit.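

In this assay, among the compounds shown here, compound 3 and compound 4 both give only limits, not numbers, so no step between them can be read. The compounds shown leave open whether methyl in place of trifluoromethyl changes growth inhibition at all.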